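This account rests on a few compounds, and the source may have more. Where it says the series, first, only, none or still open, it means among the compounds named here.

Compound 3 `O=S(=O)(c1cccc(F)c1)c1ccc2c(c1)CCC[C@H]2CN1CC(O)C1` gives 0.1 nM in an assay on isolated protein for displacement of a labelled ligand from 5-hydroxytryptamine receptor 6 (Homo sapiens) (on this read-out lower numbers stand for stronger inhibition and higher numbers for weaker inhibition), the lowest of the three numbers recorded. Compound 1 `CNCC1CCCc2cc(S(=O)(=O)c3ccccc3)ccc21` gives 0.316 nM in this assay, and compound 2 `NC[C@@H]1CCCc2cc(S(=O)(=O)c3cc(F)cc4[nH]cnc34)ccc21` gives 5.01 nM; both of those numbers lie above the number for compound 3 by more than the usual scatter, so compound 3 has the strongest inhibition among the measured compounds.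

Compound 4 `CC(C)(C)C(=O)NC[C@@H]1CCCc2cc(S(=O)(=O)c3cccc(F)c3)ccc21` has not yet been measured. It differs from compound 3 in one place: ((tert-butyl)carbonyl)amino in place of 3-hydroxyazetidin-1-yl on a saturated chain carbon bound to a saturated ring carbon. Among the compounds with values here, no pair of measured compounds shows this kind of change, so the size of the step can only be guessed from the fact that all three measured compounds carry an amine on that saturated chain carbon, while compound 4 carries an amide there instead. A large step toward weaker inhibition is expected, with wide uncertainty. For compound 4 the estimated step is a 500-fold higher number from compound 3 to compound 4 (2.70 log units; beyond the scatter). Compound 4 is therefore expected to give about 50 nM in this assay, within a range from 5 nM to 500 nM.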

Compound 4, inhibition constant: 3.98 nM
Estimate against measurement, compound 4: 13-fold (1.10 log units) above; measured number outside the range, below it.
By their numbers in this assay, from the lowest: compound 3; then compound 1; then compounds 4 and 2 (each within the scatter of the next).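

In this assay, replacing 3-hydroxyazetidin-1-yl with ((tert-butyl)carbonyl)amino on this saturated chain carbon gives a 40-fold higher number from compound 3 to compound 4 (1.60 log units; beyond the scatter), the first direct sign that inhibition depends strongly on the group at this place. The change does not abolish binding, however: with an amide in place of the amine, compound 4 still gives 3.98 nM in this assay, so an amine here is not essential for measurable inhibition in the nanomolar range. Nothing available explains why the step has this size.

What stays open is which part of the change accounts for the step, as the azetidine ring, its hydroxyl and the amine nitrogen all leave together while the carbonyl and tert-butyl enter. An acetylamino group or an open-chain dimethylamino group on the same carbon would help separate these contributions.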